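A Second Nitro Group on the Aromatic Ring

The source may hold more compounds than are shown below. What is called first, only, known or untested is meant among the compounds shown, and "the series" means these compounds.

Of the compounds shown here, three sharing one core have been measured in a functional assay on A549 cells (Homo sapiens) for inhibition, read by XTT assay, with a stated time of 48 h; a higher number here means a weaker inhibitor, a lower number a stronger inhibitor. Compound 1 `C=C(C(=O)c1ccc(OC)cc1)C(OC(=O)c1ccccc1)C(CC)CC` gives 35200 nM. Compound 2 `C=C(C(=O)c1ccc(OC)cc1)C(OC(=O)c1ccccc1)c1ccc([N+](=O)[O-])cc1` gives 66600 nM in this assay. Compound 3 `C=C(C(=O)c1ccc(OC)cc1)C(OC(=O)c1ccccc1)c1ccccc1[N+](=O)[O-]` gives 45500 nM in this assay; it stands second highest of the three numbers, nearest to compound 1 and furthest from compound 2, yet both gaps lie within the scatter. The measured steps are a 1.9-fold higher number from compound 1 to compound 2 (0.28 log units; within the scatter), a 1.3-fold higher number from compound 1 to compound 3 (0.11 log units; within the scatter) and a 1.5-fold lower number from compound 2 to compound 3 (0.17 log units; within the scatter); none of them rises above the scatter, so replacing pentan-3-yl with a nitrophenyl, or exchanging one nitrophenyl for the other, has left the read-out essentially unchanged. Compound 4 `C=C(C(=O)c1ccc(OC)cc1)C(OC(=O)c1ccccc1)c1ccc([N+](=O)[O-])cc1[N+](=O)[O-]` differs from compound 3 by nitro in place of hydrogen on an aromatic carbon. Within the data shown here, no measured pair bears directly on a second nitro group, but every step that bears on the first one was small, so the expected step from compound 3 to compound 4 in this assay is a 1.2-fold higher number from compound 3 to compound 4 (0.08 log units; within the scatter), none beyond the scatter. Compound 4 is therefore expected to give 55000 nM in this assay, with a range from 25000 nM to 130000 nM.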

Compound 4, half-maximal inhibitory concentration: 13000 nM
Estimate against measurement, compound 4: 4.2-fold (0.63 log units) above; measured number below the stated range.
By their numbers in this assay, from the lowest: compound 4; then compounds 1, 3 and 2 (each within the scatter of the next).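

Until now, every change at this site stayed within the scatter in this assay, but nitro in place of hydrogen, on the aromatic carbon meta to a nitro group and para to a large group, gives a 3.5-fold lower number from compound 3 to compound 4 (0.54 log units; beyond the scatter) and so a stronger inhibitor. Adding a nitro group to the ring of compound 2 likewise gives a 5.1-fold lower number from compound 2 to compound 4 (0.71 log units; beyond the scatter), so a ring with two nitro groups separates from both rings with one, although those two rings lie within the scatter of each other. No evidence is available to explain this shift.

The compounds shown cannot tell whether the two nitro groups must act together or whether any group at this place would do the same. An amine or a carboxylic acid in place of the second nitro group remains an open case.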